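Changing the group on the nitrogen: compound 2 to compound 3

This account rests on a few compounds, and the source may have more. Where it says the series, first, only, none or still open, it means among the compounds named here.

Compound 2 `O=[N+]([O-])c1ccc(Nc2nc(SCc3ccc(C(F)(F)F)cc3)nc3ccccc23)cc1` is the stronger of the two measured compounds: in a functional assay on PC-3 cells (Homo sapiens) for cytotoxicity, read by MTT assay, with a stated time of 72 h (a higher number here means a weaker inhibitor, a lower number a stronger inhibitor), compound 2 gives 7900 nM, while compound 1 `FC(F)(F)c1ccc(CSc2nc(Nc3ccccc3C(F)(F)F)c3ccccc3n2)cc1` gives 34800 nM. That single step, a 4.4-fold lower number from compound 1 to compound 2 (0.64 log units; beyond the scatter), came from 4-nitrophenyl in place of 2-(trifluoromethyl)phenyl on a nitrogen on an aromatic ring. Compound 3 `Fc1ccc(Nc2nc(SCc3ccc(C(F)(F)F)cc3)nc3ccccc23)cc1Cl` differs from compound 2 by 3-chloro-4-fluorophenyl in place of 4-nitrophenyl on a nitrogen on an aromatic ring. Going by the values given here, no measured step compares a nitro-bearing ring with a halogen-bearing one, so the earlier step is only a loose guide to a modest shift. Compound 3 is therefore expected to show a 1.5-fold higher number from compound 2 to compound 3 (0.18 log units; within the scatter) in this assay, with an estimate of 12000 nM and a range of 4000 nM to 40000 nM.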

Compound 3, half-maximal inhibitory concentration: 18600 nM
For compound 3 the middle estimate is 1.6-fold (0.19 log units) below the measured one; the measured number falls inside the stated range.
By their numbers in this assay, from the lowest: compound 2; then compounds 3 and 1 (each within the scatter of the next).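

In this assay, the 3-chloro-4-fluorophenyl ring on this nitrogen does not match the 4-nitrophenyl ring, with (a 2.4-fold higher number from compound 2 to compound 3 (0.37 log units; beyond the scatter)). It cannot be told apart from the 2-(trifluoromethyl)phenyl ring, with (a 1.9-fold lower number from compound 1 to compound 3 (0.27 log units; within the scatter)), so among these three rings only 4-nitrophenyl stands clear of both others. Nothing available here explains these differences. From the compounds shown here alone, what a plain phenyl ring, or a ring bearing a methoxy group or a carboxylic acid, would give on this nitrogen remains open.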